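The source may hold more compounds than are shown below. What is called first, only, known or untested is meant among the compounds shown, and "the series" means these compounds.

In a functional assay on cells (Homo sapiens) for antiproliferative activity, read by MTT assay, with a stated time of 48 h (a higher number here means a weaker inhibitor, a lower number a stronger inhibitor), compound 1 `CCN(CC)CCn1c(N)c(-c2nc3ccccc3n2C)c2nc(C#N)c(C#N)nc21` gives > 50000 nM as a limit of the assay and not a number. Compound 2 `CN(C)CCCn1c(N)c(-c2nc3ccccc3n2C)c2nc(C#N)c(C#N)nc21` gives 3670 nM and compound 3 `CCN(CC)CCCn1c(N)c(-c2nc3ccccc3n2C)c2nc(C#N)c(C#N)nc21` gives 6750 nM there, so these two stand level: a 1.8-fold higher number from compound 2 to compound 3 (0.26 log units; within the scatter) separates them. Compound 4 `CCN(CC)CCCCn1c(N)c(-c2nc3ccccc3n2C)c2nc(C#N)c(C#N)nc21` differs from compound 3 by (diethylamino)methyl in place of diethylamino on a saturated chain carbon, three bonds along the chain from an aromatic nitrogen and so has 4-(diethylamino)butyl where compound 3 has 3-(diethylamino)propyl. The same change at two bonds along the chain gave an at least 7.4-fold lower number from compound 1 to compound 3 (0.86 log units; beyond the scatter) but that step starts from a limit, and it is the only one of its kind. Its size therefore does not carry over, and no step beyond the scatter is expected in this assay here. The estimated step is small: a 1.4-fold lower number from compound 3 to compound 4 (0.13 log units; within the scatter). For compound 4 the expected value is 5000 nM with an estimated range of 1500 nM to 18000 nM.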

Compound 4, half-maximal inhibitory concentration: 2890 nM
The estimate for compound 4 lay 1.7-fold (0.24 log units) above the measured number; measured number inside the range.
By their numbers in this assay, from the lowest: compounds 4, 2 and 3 (each within the scatter of the next, the first and the last beyond it). At a limit, above all of these: compound 1.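

Going from 3-(diethylamino)propyl to 4-(diethylamino)butyl gives a 2.3-fold lower number from compound 3 to compound 4 (0.37 log units; beyond the scatter), the first step of this change that starts and ends on real numbers, and it is modest. With a 1.3-fold lower number from compound 2 to compound 4 (0.10 log units; within the scatter), compound 4 and compound 2 stand level. The step from the 2-(diethylamino)ethyl chain, an at least 17-fold lower number from compound 1 to compound 4 (1.23 log units; beyond the scatter), starts from a limit of compound 1 and not from a number: the limit of > 50000 nM in this assay, at which 1 of the 4 values shown sits.

From the compounds shown here alone, whether a longer chain, such as 5-(diethylamino)pentyl, would continue this trend remains open. So does the effect of a ring amine, such as piperidine or morpholine, in place of diethylamino.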